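Taking the methoxy group off compound 2

A few compounds are considered here, and "the series" means these few. Any claim that something is new, unique, unknown or untested is made for them only; others in the source may bear on it.

Of the compounds shown here, three have been measured in a functional assay on Hs-578T cells (Homo sapiens) for inhibition, read by sulforhodamine B assay, with a stated time of 48 h, tested at 10 uM; on this read-out higher numbers stand for more inhibition of growth at the one concentration tested and lower numbers for less inhibition of growth. Compound 2 `COc1ccc(-c2nc3sc(-c4ccccc4)cn3n2)cc1` gives 40%, the middle of the three numbers. Compound 1 `C/C(=N\O)c1ccc(NC(=O)Cn2nc(-c3ccc(Cl)cc3)nc2N)cc1`, built quite differently, lies lower at 11.2%, and compound 3 `COc1ccc(-c2nc3sc(-c4ccc(Cl)cc4)cn3n2)cc1` lies higher at 73%.

Compound 4 `c1ccc(-c2nc3sc(-c4ccccc4)cn3n2)cc1` departs from compound 2 at one place, with hydrogen in place of methoxy on an aromatic carbon. Within the data shown here, only one measured step comes close to this change. Chloro in place of hydrogen on an aromatic carbon gave a number 33 percentage points higher from compound 2 to compound 3 (beyond the scatter), a large move beyond the scatter. Among the measured compounds shown here, that step shows that a single replacement can matter in this pair, but it does not involve the methoxy group, and no measured step does. It therefore gives no direction for the new change, and the expectation stays anchored on compound 2 at 40%. The estimate is an expected a number 5 percentage points lower from compound 2 to compound 4 (within the scatter), which is no step beyond the scatter, although the uncertainty is wide. Compound 4 is expected at 35%, with an estimated range from 15% to 58%.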

Compound 4, percent growth inhibition at one concentration: 9%
For compound 4 the middle estimate is 26 percentage points above the measured one; measured number below the stated range.
By their numbers in this assay, from the lowest: compounds 4 and 1 (each within the scatter of the next); then compound 2; then compound 3.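

In this assay the methoxy group of compound 2 proves to be no passive substituent: there is a number 31 percentage points lower from compound 2 to compound 4 (beyond the scatter) when hydrogen takes its place on this aromatic carbon, para to a large group. Among these compounds, until now the only large single change on record was a chloro replacing a hydrogen elsewhere in the molecule, and this result shows that the methoxy position is just as sensitive to a single replacement, with the number falling rather than rising. Compound 2 therefore sits between two large steps in opposite directions, each made at a different place. Nothing available here bears on why removing the methoxy group has this effect.

On these data alone, it remains open whether the oxygen or the whole methoxy group carries this difference, which a hydroxy, methyl or amino group at the same place could help to separate. As far as these compounds go, it is also open whether the chloro replacement would give a similar rise in a compound that carries hydrogen in place of the methoxy group.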